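A Pyrimidine Swapped for a Carbon Ring

The source may report more compounds than this note shows. Statements on the series, on what has been measured and on what is new or still open speak of the compounds shown alone.

Three compounds share one core and differ in the group on the amide-type nitrogen. In an ADME assay on MT4 cells (Homo sapiens) for cytotoxicity, read by MTT assay (a higher number here means that more compound is tolerated, a lower number that less compound is tolerated), compound 1 `Cc1cc(C)cc(S(=O)(=O)c2c(C(=O)NCc3ccccc3O)[nH]c3ccc(Cl)cc23)c1` gives 23800 nM. In the same test, compound 2 `Cc1cc(C)cc(S(=O)(=O)c2c(C(=O)NC(C)c3cccc(O)c3)[nH]c3ccc(Cl)cc23)c1` gives 16000 nM, which amounts to a 1.5-fold lower number from compound 1 to compound 2 (0.17 log units; within the scatter). Compound 3 `Cc1cc(C)cc(S(=O)(=O)c2c(C(=O)NCc3cc(O)ncn3)[nH]c3ccc(Cl)cc23)c1` gives > 53000 nM, and this is a limit of the assay, not a number. Even so, the limit places it clear of the other two, with an at least 2.2-fold higher number from compound 1 to compound 3 (0.34 log units; beyond the scatter) and an at least 3.3-fold higher number from compound 2 to compound 3 (0.52 log units; beyond the scatter).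

Compound 4 `Cc1cc(C)cc(S(=O)(=O)c2c(C(=O)NCc3ccc(CO)cc3)[nH]c3ccc(Cl)cc23)c1` departs from compound 3 by one change, 4-(hydroxymethyl)phenyl in place of 6-hydroxypyrimidin-4-yl on a saturated chain carbon bound to an amide-type nitrogen: 4-(hydroxymethyl)phenyl in place of 6-hydroxypyrimidin-4-yl. It therefore gives up the ring with two hetero atoms for an aromatic ring of carbon only, the ring type that compound 1 and compound 2 carry. Within the data shown here, those two compounds stay within the scatter of each other, so they suggest that compound 4 should land near them, although no measured compound carries this exact group. A fall of modest size is therefore expected, the reverse of the steps into compound 3, and the estimated step is an at least 2.1-fold lower number from compound 3 to compound 4 (0.32 log units; beyond the scatter). The estimated value for compound 4 is 25000 nM, with an expected range of 11000 nM to 55000 nM.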

Compound 4, half-maximal cytotoxic concentration: 31100 nM
The estimate for compound 4 lay 1.2-fold (0.09 log units) below the measured number; the range from low to high includes it.
By their numbers in this assay, from the lowest: compounds 2, 1 and 4 (each within the scatter of the next). At a limit, above all of these: compound 3.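

Compound 4 shows that a third ring of carbon only, this one carrying its hydroxyl on a hydroxymethyl group, stays with the first two in this assay: the steps are a 1.3-fold higher number from compound 1 to compound 4 (0.12 log units; within the scatter) and a 1.9-fold higher number from compound 2 to compound 4 (0.29 log units; within the scatter). Across these three compounds, the different groups on the amide-type nitrogen therefore make no difference that can be told from the scatter. Leaving 6-hydroxypyrimidin-4-yl for 4-(hydroxymethyl)phenyl gives an at least 1.7-fold lower number from compound 3 to compound 4 (0.23 log units; that floor lies within the scatter), and the true size of this change stays unknown because the value of compound 3 is a limit of the assay, not a number: the limit of > 53000 nM in this assay, at which 1 of the 4 values shown sits.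

The compounds shown leave open whether the higher tolerated concentration of compound 3 belongs to the ring nitrogens of its group or to the whole 6-hydroxypyrimidin-4-yl group, and a pyridine ring, with a single ring nitrogen, would help to separate the two. They also leave open how this assay would read with an amine or a carboxylic acid on the ring of carbon in place of the hydroxymethyl group of compound 4.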